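From trifluorophenyl to dihydroxyphenyl: compound 3 to compound 4

A few compounds are considered here, and "the series" means these few. Any claim that something is new, unique, unknown or untested is made for them only; others in the source may bear on it.

Values in a functional assay on MCF cells (Homo sapiens) for antiproliferative activity, with a stated time of 72 h; on this read-out lower numbers stand for stronger inhibition and higher numbers for weaker inhibition:
- compound 1 `OC[C@H]1O[C@@H](n2cnc3c(NCc4ccc(Cl)cc4)ncnc32)[C@H](O)[C@@H]1O` gives > 166000 nM as a limit
- compound 2 `OC[C@H]1O[C@@H](n2cnc3c(NCc4ccc(F)c(F)c4F)ncnc32)[C@H](O)[C@@H]1O` gives > 166000 nM as a limit
- compound 3 `OC[C@H]1O[C@@H](n2cnc3c(NCc4c(F)ccc(F)c4F)ncnc32)[C@H](O)[C@@H]1O` gives > 166000 nM as a limit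

Compound 3 stands at > 166000 nM, which is a limit and not a number. The whole set sits at one limit: the limit of > 166000 nM in this assay, at which 3 of the 3 values shown sit.

Compound 4 `OC[C@H]1O[C@@H](n2cnc3c(NCc4cccc(O)c4O)ncnc32)[C@H](O)[C@@H]1O` is next, and the change is 2,3-dihydroxyphenyl in place of 2,3,6-trifluorophenyl on a saturated chain carbon bound to a nitrogen on an aromatic ring. In short, 2,3-dihydroxyphenyl replaces 2,3,6-trifluorophenyl on a saturated chain carbon bound to a nitrogen on an aromatic ring.

Going by the values given here, three measured steps bear on this: a step that the two limits leave unreadable from compound 1 to compound 2, a step that the two limits leave unreadable from compound 1 to compound 3 and a step that the two limits leave unreadable from compound 2 to compound 3. None has a readable size. Among the compounds with values here, no measured compound carries 2,3-dihydroxyphenyl, so these steps give no measure for this change, and the range stays wide.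

The estimate means an at least 2.7-fold lower number from compound 3 to compound 4 (0.44 log units; beyond the scatter), expected toward stronger inhibition, though this assay may again report only a limit. For compound 4 the estimated value is 60000 nM, with an expected range from 5000 nM to 166000 nM.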

Compound 4, half-maximal inhibitory concentration: 5200 nM
Compound 4: the middle estimate sits 12-fold (1.06 log units) above what was measured, and the stated range covers the measured number.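

In this assay, the saturated chain carbon bound to a nitrogen on an aromatic ring proves to be a place where the aryl group matters: 2,3-dihydroxyphenyl gives an at least 31-fold lower number from compound 3 to compound 4 (1.50 log units; beyond the scatter), and the same holds against the other two groups, with an at least 31-fold lower number from compound 2 to compound 4 (1.50 log units; beyond the scatter) and an at least 31-fold lower number from compound 1 to compound 4 (1.50 log units; beyond the scatter). Each of these sizes is only a floor, and the steps among compound 1, compound 2 and compound 3 cannot be read. Compound 4 alone gives a readable number, while the other three stay at one limit: the limit of > 166000 nM in this assay, at which 3 of the 4 values shown sit.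

Going by these compounds, how far the true values of compound 1, compound 2 and compound 3 lie from that of compound 4 remains open. Also open, on these data alone, is whether a single hydroxyl, two methoxy groups or an amine on the phenyl ring would give a readable number at this place.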